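Does a cyclohexyl ring raise the stability of compound 2?

A few compounds are considered here, and "the series" means these few. Any claim that something is new, unique, unknown or untested is made for them only; others in the source may bear on it.

Measured so far in an ADME assay on microsomes from liver (Mus musculus) for metabolic stability, read by LC-MS, with a stated time of 10 min; on this read-out lower numbers stand for a less stable compound and higher numbers for a more stable compound:
Compound 1 `FC1(F)CCC(CN(C[C@H]2Cc3c(cccc3N3CCNCC3)CN2)[C@H]2CCCc3cccnc32)CC1` gives 76.6%
Compound 2 `CCN(C[C@H]1Cc2c(cccc2N2CCNCC2)CN1)[C@H]1CCCc2cccnc21` gives 53.8%
Compound 3 `CN(C[C@H]1Cc2c(cccc2N2CCN(c3ncccn3)CC2)CN1)[C@H]1CCCc2cccnc21` gives 35.1%

Among these three numbers, compound 2 holds the second highest place, with compound 3 lower at 35.1% and compound 1 higher at 76.6% on the same read-out. The next compound to be tested, compound 4 `c1cnc2c(c1)CCC[C@@H]2N(CC1CCCCC1)C[C@H]1Cc2c(cccc2N2CCNCC2)CN1`, changes compound 2 in one place: cyclohexyl in place of methyl on a saturated chain carbon bound to an amine nitrogen. In words, this is cyclohexyl in place of methyl on a saturated chain carbon bound to an amine nitrogen.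

Within the data shown here, one measured step bears on this change: a number 22.8 percentage points lower from compound 1 to compound 2 (beyond the scatter), with methyl in place of 4,4-difluorocyclohexyl at that same kind of place. Read backwards, that step links the ring with the higher number. Among the measured compounds shown here, the ring in compound 4 carries no fluorine, however, and no measured pair isolates the fluorines, so perhaps only part of that rise carries over. Compound 3 differs from compound 2 in more than one place and offers no direct guide.

A rise in this assay is therefore expected, somewhat smaller than the measured step. The expected change is a number 14.2 percentage points higher from compound 2 to compound 4 (beyond the scatter) in size. For compound 4 the estimate is 68% and the expected range runs from 52% to 82% on this scale.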

Compound 4, percent of the compound remaining: 85.6%
Beside the measured number, compound 4's estimate is 17.6 percentage points below it; the whole stated range lies below it.
By their numbers in this assay, from the lowest: compound 3; then compound 2; then compounds 1 and 4 (each within the scatter of the next).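

In this assay, a ring with no fluorine at all, placed on a saturated chain carbon bound to an amine nitrogen, gives a large rise over methyl: a number 31.8 percentage points higher from compound 2 to compound 4 (beyond the scatter). The earlier step with 4,4-difluorocyclohexyl could not show this, since the ring and its fluorines arrived together, so the rise could have depended on the fluorines. Swapping the two rings now gives a number 9 percentage points higher from compound 1 to compound 4 (within the scatter), and because that step lies within the scatter, this read-out cannot tell cyclohexyl and 4,4-difluorocyclohexyl apart at this place, so the fluorines show no measurable effect of their own here. Nothing in the data gives a reason for the rise over methyl.

The compounds shown leave open whether the ring itself matters or whether an open chain such as hexyl would give a similar number. They also leave open how small the ring can be, for example whether cyclopropyl at the same place would keep the number near that of compound 4 or fall back towards that of compound 2.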